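The source may report more compounds than this note shows. Statements on the series, on what has been measured and on what is new or still open speak of the compounds shown alone.

Within the data shown here, compound 2, `COc1cc(/C=C/C(C)=O)ccc1OCc1cn(-c2ccc(C)cc2)nn1`, is one of two compounds measured in a functional assay on PC-3 cells (Homo sapiens) for antiproliferative activity, read by MTT assay, with a stated time of 48 h; on this read-out higher numbers stand for weaker inhibition and lower numbers for stronger inhibition. Its companion, compound 1, `COc1cc(/C=C/C(C)=O)ccc1OCc1cn(-c2c(F)cccc2F)nn1`, differs from it only in the group on the aromatic nitrogen of the shared core. In this assay compound 1 gives 24200 nM, and compound 2 gives 58100 nM, the higher of the two numbers. Among the measured compounds shown here, the single measured step, a 2.4-fold higher number from compound 1 to compound 2 (0.38 log units; beyond the scatter), is therefore the only guide to how a change at this position plays out.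

Compound 3, `COc1cc(/C=C/C(C)=O)ccc1OCc1cn(-c2cc(F)cc(Br)c2)nn1`, carries the change (3-bromo-5-fluorophenyl in place of 4-methylphenyl on an aromatic nitrogen). For the measured compounds named here, the one step that bears on it runs the other way, from a halogenated phenyl toward a methylphenyl, and was modest in size. Compound 3 returns to a halogenated phenyl, though with a different pattern of halogens from compound 1, so a move back in the direction of compound 1 is the most that can be read from the numbers shown, and a modest one at that. Compound 3 is therefore expected to give a somewhat lower number than compound 2, a step of about a 1.9-fold lower number from compound 2 to compound 3 (0.29 log units; within the scatter) in this assay. The estimated value of compound 3 in this assay is 30000 nM, within a range from 10000 nM to 90000 nM.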

Compound 3, half-maximal inhibitory concentration: 56900 nM
Estimate against measurement, compound 3: 1.9-fold (0.28 log units) below; measured number inside the range.
By their numbers in this assay, from the lowest: compound 1; then compounds 3 and 2 (each within the scatter of the next).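

Replacing the 4-methylphenyl with 3-bromo-5-fluorophenyl on the aromatic nitrogen gives, in this assay, a 1.0-fold lower number from compound 2 to compound 3 (0.01 log units; within the scatter), so at this position these two groups cannot be told apart on this read-out. Halogens on the phenyl ring therefore do not by themselves bring the number down to that of compound 1: moving away from the 2,6-difluorophenyl gives a 2.4-fold higher number from compound 1 to compound 3 (0.37 log units; beyond the scatter), a modest step beyond the scatter, and compound 3 goes against any reading that a halogenated phenyl sets the lower number, leaving compound 1 the only one of the three to stand apart. Nothing available here bears on why the numbers fall this way.

On these data alone, it remains open whether the lower number of compound 1 belongs to the 2,6-difluorophenyl specifically or would also appear with an unsubstituted phenyl, a 2-fluorophenyl or a 2,6-dichlorophenyl. Also open, as far as these compounds go, is how this position would respond to a group of another kind, such as an amine or a carboxylic acid on the phenyl ring, or a longer alkyl chain in place of the ring.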